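This account rests on a few compounds, and the source may have more. Where it says the series, first, only, none or still open, it means among the compounds named here.

Three nitrofuran amides have been tested in an ADME assay on Vero cells (Chlorocebus sabaeus) for cytotoxicity, read by MTT assay, with a stated time of 48 h; on this read-out lower numbers stand for higher toxicity in this test and higher numbers for lower toxicity in this test. Compound 1 `O=C(NCc1cccc(Cl)c1)c1ccc([N+](=O)[O-])o1` gives 5500 nM, and compound 3 `O=C(NCc1ccc(Oc2ccc(Cl)cc2)cc1)c1ccc([N+](=O)[O-])o1` gives 8400 nM. Compound 2 `CC(C)(NC(=O)c1ccc([N+](=O)[O-])o1)c1ccccc1` gives only a limit of the test, > 180000 nM, which is where the limit of > 180000 nM in this assay, at which 1 of the 3 values shown sits, stands. Of the three values shown, compound 2 therefore holds the end of the range at which the test reports no number.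

Compound 4 `CC(C)(NC(=O)c1ccc([N+](=O)[O-])o1)c1ccc(COc2ccc(Cl)cc2)cc1` is compound 2 with one change: (4-chlorophenoxy)methyl in place of hydrogen on an aromatic carbon, placed on an aromatic carbon of a six-membered aromatic ring of carbon only, para to a large group. Among the measured compounds shown here, no measured pair follows this exact change, so the size of the step is an expectation only; the step of an at least 6.0-fold lower number from compound 2 to compound 4 (0.77 log units; beyond the scatter) is expected to run towards higher toxicity in this assay, beyond the scatter. Compound 4 is expected to give about 30000 nM, with a range from 8000 nM to 150000 nM.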

Compound 4, half-maximal cytotoxic concentration: 120000 nM
The estimate for compound 4 lay 4.0-fold (0.60 log units) below the measured number; low and high end bracket the measured number.
By their numbers in this assay, from the lowest: compounds 1 and 3 (each within the scatter of the next); then compound 4. At a limit, above all of these: compound 2.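

In this assay, placing (4-chlorophenoxy)methyl on an aromatic carbon, para to a large group, gives a measured number where the parent compound gave none, and the change brings an at least 1.5-fold lower number from compound 2 to compound 4 (0.17 log units; that floor lies within the scatter). Compound 2 holds only a limit, so the step has a floor but no known size: the limit of > 180000 nM in this assay, at which 1 of the 4 values shown sits.

The compounds shown leave open whether a smaller group at this place, such as chlorine or methoxy, would also give a number under that limit. They also leave open how an amine or a carboxylic acid there would read.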